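Ring contraction on the amide nitrogen: compound 1 to compound 3

This account rests on a few compounds, and the source may have more. Where it says the series, first, only, none or still open, it means among the compounds named here.

Within the data shown here, compound 1 `CC(C)N1CC[C@H](NC(=O)c2cc(-c3ccc(NS(=O)(=O)c4cccc(Cl)c4Cl)cc3)nc3[nH]ncc23)C1` gives 4 nM in an assay for inhibition of serine/threonine-protein kinase Sgk1 (Homo sapiens), with stated times of 30 min and 60 min, in the presence of a further agent that is not named here (a lower number here means a stronger inhibitor, a higher number a weaker inhibitor), and stands highest of the two numbers measured so far; compound 2 `O=C(NC1CCN(CC2CC2)C1)c1cc(-c2ccc(NS(=O)(=O)c3cccc(Cl)c3Cl)cc2)nc2[nH]ncc12` gives 1 nM in this assay. Among the measured compounds shown here, the single measured step, a 4.0-fold lower number from compound 1 to compound 2 (0.60 log units; beyond the scatter), alters only the group on the ring nitrogen while the ring itself is unchanged. Compound 3 `CN1CC(NC(=O)c2cc(-c3ccc(NS(=O)(=O)c4cccc(Cl)c4Cl)cc3)nc3[nH]ncc23)C1` differs from compound 1 by 1-methylazetidin-3-yl in place of 1-isopropylpyrrolidin-3-yl on an amide-type nitrogen. For the measured compounds named here, no measured step changes the ring, so the direction is open; a small step in either direction, or none beyond the scatter, is expected. Compound 3 is estimated at 6 nM, within 2 nM to 20 nM, an expected step of a 1.5-fold higher number from compound 1 to compound 3 (0.18 log units; within the scatter).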

Compound 3, half-maximal inhibitory concentration: < 1 nM
Compound 3 gave a limit, no number; the forecaster's own chance of this, stated with the estimate: 2%; middle value at least 6.0-fold (0.77 log units) from the limit.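

In this assay compound 3 gives < 1 nM, a limit of the assay and not a number. The amide nitrogen therefore accepts 1-methylazetidin-3-yl, with a four-membered ring and no defined stereocentre, without loss, the step being an at least 4.0-fold lower number from compound 1 to compound 3 (0.60 log units; beyond the scatter). The other step, a number no higher from compound 2 to compound 3 (the limit leaves the size open), cannot be read in size, so the order at the low end stays unresolved: the limit of < 1 nM in this assay, at which 1 of the 3 values shown sits.

The ring and its nitrogen substituent change together, so neither can be credited with the step. From the compounds shown here alone, whether 1-methylpyrrolidin-3-yl or an open-chain 2-(dimethylamino)ethyl group would hold this level remains open.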